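The compounds below may be only part of what the source reports. "The series", "measured", "known", "first", "only" and "open" are said of these compounds alone.

Measured in a physicochemical assay for lipophilicity, read by HPLC, at pH 7.4; on this read-out higher numbers stand for higher lipophilicity and lower numbers for lower lipophilicity:
- compound 1 `O=C(O)CCn1c(=O)oc2cc(OCC3CCC3)c(Cl)cc21`: 2.9
- compound 2 `C[C@@H](Oc1cc2oc(=O)n(CCC(=O)O)c2cc1Cl)c1cccnn1`: 0.83

Compound 2 holds the lower of the two numbers, at 0.83, and compound 1 lies beyond the scatter above it. Compound 3 `CCOc1cc2oc(=O)n(CCC(=O)O)c2cc1Cl` is not yet measured, and its change from compound 2 is hydrogen in place of pyridazin-3-yl on a saturated chain carbon bound to an oxygen on an aromatic ring and a saturated chain carbon. For the measured compounds named here, the one measured step that bears on this is a number 2.07 log units lower from compound 1 to compound 2 (beyond the scatter), which is large and beyond the scatter and also changed the group on the oxygen on an aromatic ring. Compound 3 loses the aromatic ring that entered in that step, but it also has no four-membered ring there, unlike compound 1 at 2.9. A return only part of the way up is therefore expected. In this assay a rise beyond the scatter is expected, estimated as a number 0.87 log units higher from compound 2 to compound 3 (beyond the scatter). For compound 3 the estimated value is 1.7, with an expected range of 1.2 to 2.2.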

Compound 3, distribution coefficient: 1.49
Estimate against measurement, compound 3: 0.21 log units above; low and high end bracket the measured number.
By their numbers in this assay, from the lowest: compound 2; then compound 3; then compound 1.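

In this assay, hydrogen in place of pyridazin-3-yl on the saturated chain carbon gives a number 0.66 log units higher from compound 2 to compound 3 (beyond the scatter), a modest step. Methyl in place of cyclobutyl on the saturated chain carbon gives a number 1.41 log units lower from compound 1 to compound 3 (beyond the scatter), a large step. Together these divide the earlier two-place change, a number 2.07 log units lower from compound 1 to compound 2 (beyond the scatter), into one step for each place, with compound 3 lying between the other two compounds. No measurement on hand accounts for either step.

A phenyl ring in place of pyridazin-3-yl would show whether the step follows the ring itself or its two nitrogens. As far as these compounds go, whether a longer chain or an amine on the same carbon would fit this order remains open, as does whether the steps hold with an amide in place of the carboxylic acid.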